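A few compounds are considered here, and "the series" means these few. Any claim that something is new, unique, unknown or untested is made for them only; others in the source may bear on it.

Measured in a functional assay on M21 cells (Homo sapiens) for inhibition, read by sulforhodamine B assay, with a stated time of 48 h; a higher number here means a weaker inhibitor of growth, a lower number a stronger inhibitor of growth:
- compound 1 `c1ccc(Oc2ccc(NC3=NCCO3)cc2)cc1`: 3100 nM
- compound 2 `c1ccc(COc2ccc(NC3=NCCO3)cc2)cc1`: 15900 nM
- compound 3 `O=C(CCl)NC(=O)Nc1cccc(OC2CCCC2)c1`: 3500 nM

Among these three, compound 3 gives 3500 nM, which lies within the usual scatter of compound 1, while compound 2 gives a number higher than compound 3 by more than the scatter. Compound 4 `O=C(CCl)NC(=O)Nc1cccc(OC2CCCCCC2)c1` has cycloheptyl in place of cyclopentyl on an oxygen on an aromatic ring. Within the data shown here, no measured pair here shows what a change of this kind does, so the expectation is cautious: no shift beyond the scatter in this assay, and no firm direction. The expected step is a 1.2-fold lower number from compound 3 to compound 4 (0.07 log units; within the scatter). For compound 4 the estimated value is 3000 nM, with an expected range of 1300 nM to 7000 nM.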

Compound 4, concentration for 50% growth inhibition: 4200 nM
Compound 4: the middle estimate sits 1.4-fold (0.15 log units) below what was measured, within the range that was stated.
By their numbers in this assay, from the lowest: compounds 1, 3 and 4 (each within the scatter of the next); then compound 2.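

Replacing cyclopentyl with cycloheptyl on an oxygen on an aromatic ring gives a 1.2-fold higher number from compound 3 to compound 4 (0.08 log units; within the scatter) in this assay. This first one-place comparison shows that, in this pair, the ring size can change without a shift that stands clear of the usual scatter. Nothing available explains this result.

The compounds shown leave open whether a ring is needed on this oxygen at all, since a straight hexyl chain could be compared with cycloheptyl. They also leave open whether a ring carrying an amine would give a similar number.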